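Replacing the amide aryl group with a thiazole

A few compounds are considered here, and "the series" means these few. Any claim that something is new, unique, unknown or untested is made for them only; others in the source may bear on it.

Measured compounds:
compound 1 `Cc1cc(C(=O)Nc2cccc(-c3ccnc4c(N)cccc34)c2)ccc1Br` gives 9900 nM
compound 2 `Nc1cccc2c(-c3cccc(NC(=O)c4cc(Cl)cc(C(F)(F)F)c4)c3)ccnc12` gives 18500 nM
compound 3 `Nc1cccc2c(-c3cccc(NC(=O)c4cc(C(F)(F)F)cc(C(F)(F)F)c4)c3)ccnc12` gives 3400 nM

All three share the same core and differ only in the aromatic group attached to the amide carbonyl. In a functional assay on A375P cells (Homo sapiens) for antiproliferative activity, read by MTT assay, with a stated time of 48 h (a higher number here means a weaker inhibitor, a lower number a stronger inhibitor), compound 1 gives 9900 nM, the second highest of the three numbers. Compound 2 gives 18500 nM, a difference from compound 1 that lies within the usual scatter, so no order between them can be claimed. Compound 3 gives 3400 nM, and the gap to compound 1 is beyond the scatter.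

For the measured compounds named here, the only single change measured so far is a 5.4-fold lower number from compound 2 to compound 3 (0.74 log units; beyond the scatter). It shows that swapping one substituent on the amide aryl group can move this assay by a modest amount.

Compound 4 `Nc1cccc2c(-c3cccc(NC(=O)c4nccs4)c3)ccnc12` differs from compound 1 by 1,3-thiazol-2-yl in place of 4-bromo-3-methylphenyl on a carbonyl carbon. Going by the values given here, no measured step exchanges the whole aryl group for a small heteroaryl, so the measured steps bear on it only loosely. The expectation is therefore a step of a 1.5-fold higher number from compound 1 to compound 4 (0.18 log units; within the scatter), with a wide range. Compound 4 is estimated at 15000 nM, expected between 4000 nM and 50000 nM.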

Compound 4, half-maximal inhibitory concentration: 16700 nM
Estimate against measurement, compound 4: 1.1-fold (0.05 log units) below; the measured number falls inside the stated range.
By their numbers in this assay, from the lowest: compound 3; then compounds 1, 4 and 2 (each within the scatter of the next).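

In this assay the exchange of the whole group on the carbonyl carbon gives a 1.7-fold higher number from compound 1 to compound 4 (0.23 log units; within the scatter), so this position accepts 1,3-thiazol-2-yl in place of 4-bromo-3-methylphenyl without a difference that can be told from the scatter. The earlier step changed only one substituent on a six-membered carbon ring, whereas this one replaces that ring with a smaller five-membered aromatic ring holding hetero atoms, and the two numbers still cannot be ordered. Nothing available accounts for this similarity.

Going by these compounds, whether the nitrogen or the sulfur of the thiazole matters remains open, as a thiophene or a furan on the carbonyl carbon would be needed to test this. Also open, on these data alone, is how a non-aromatic group, such as a piperidine or a short alkyl chain, would behave at this position.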